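Swapping the aryl group on a quinoline thiosemicarbazone

A few compounds are considered here, and "the series" means these few. Any claim that something is new, unique, unknown or untested is made for them only; others in the source may bear on it.

Three compounds share an aryl thiosemicarbazone arrangement and were tested in a functional assay on HT-29 cells (Homo sapiens) for antiproliferative activity, read by sulforhodamine B assay, with a stated time of 72 h; on this read-out lower numbers stand for stronger inhibition and higher numbers for weaker inhibition. Compound 1 `N#Cc1ccc(NC(=S)N/N=C/c2ccc3ccccc3n2)cc1` gives 15600 nM, the second highest of the three numbers. Compound 3 `FC(F)(F)c1ccc(NC(=S)N/N=C/c2ccc3ccccc3n2)cc1` gives 63900 nM, and the single-point step a 4.1-fold higher number from compound 1 to compound 3 (0.61 log units; beyond the scatter) is the only one measured here. Compound 2 `CN(C)C(=S)N/N=C/c1nc2ccccc2s1`, built on a different core with a dimethyl thiocarbonyl end, gives 250 nM, far lower than compound 1.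

The untested compound 4 `COc1ccccc1NC(=S)N/N=C/c1ccc2ccccc2n1` keeps the core of compound 1 and changes one part: 2-methoxyphenyl in place of 4-cyanophenyl on an amide-type nitrogen. Going by the values given here, no measured step describes a methoxy group entering this position, so the nearest guide is the change from compound 1 to compound 3, where a different group on the same phenyl ring moved the number by a modest amount. The step from compound 1 to compound 4 is therefore expected to be small, on either side of the value for compound 1, with only a modest chance of leaving the scatter. Compound 4 is expected to give 20000 nM, with a range from 5000 nM to 80000 nM, which means an expected step of a 1.3-fold higher number from compound 1 to compound 4 (0.11 log units; within the scatter).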

Compound 4, half-maximal inhibitory concentration: > 100000 nM
Compound 4: only a limit was reported; the forecaster's own chance of this, stated with the estimate: 15%; middle value at least 5.0-fold (0.69 log units) from the limit.
By their numbers in this assay, from the lowest: compound 2; then compound 1; then compound 3. At a limit, above all of these: compound 4.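

Compound 4 carries only a limit in this assay, not a number: the limit of > 100000 nM in this assay, at which 1 of the 4 values shown sits. Even so, the step can be read as a lower bound, an at least 6.4-fold higher number from compound 1 to compound 4 (0.80 log units; beyond the scatter), and it comes from 2-methoxyphenyl in place of 4-cyanophenyl on the amide-type nitrogen, with the shared core left unchanged. Alongside the earlier step, a 4.1-fold higher number from compound 1 to compound 3 (0.61 log units; beyond the scatter), this shows that the aryl group on this nitrogen matters in this assay: both replacements of 4-cyanophenyl shown here give a higher number beyond the scatter, and the exchange of one substituted phenyl for another is enough to take the compound out of the measurable range.

Still open, from the compounds shown here alone, is how far beyond the limit compound 4 really lies, and whether the loss belongs to the methoxy group itself or to where it sits on the ring. Also open, going by these compounds, is whether an unsubstituted phenyl, or a ring carrying an amine or a carboxylic acid, would give a number lower than, or close to, that of compound 1, and what the dimethyl end of compound 2 would do on the core of compound 1.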